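The source may report more compounds than this note shows. Statements on the series, on what has been measured and on what is new or still open speak of the compounds shown alone.

Measured compounds:
compound 1, `N=c1sc2cc(OC(F)(F)F)ccc2n1CCS(N)(=O)=O`: 6 mg/kg
compound 2, `CSCCn1c(=N)sc2cc(OC(F)(F)F)ccc21`: 1 mg/kg

Among the compounds with values here, in a functional assay on the whole organism with Rattus norvegicus as the target (on this read-out lower numbers stand for an effect already at smaller amounts and higher numbers for an effect only at larger amounts of compound), compound 2 gives the lowest of the two numbers so far, and compound 1 gives the higher one. Within the data shown here, the one step among the measured pair, a 6.0-fold lower number from compound 1 to compound 2 (0.78 log units; beyond the scatter), showed that the nature of the group on this chain carbon can move the number well beyond the scatter.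

Compound 3, `CNCCn1c(=N)sc2cc(OC(F)(F)F)ccc21`, has not been measured. It differs from compound 2 in one place: methylamino in place of methylsulfanyl on a saturated chain carbon, two bonds along the chain from an aromatic nitrogen. Among the measured compounds shown here, no measured step exchanges a methylsulfanyl for a methylamino, so the only guidance is that the step from compound 1 to compound 2 changed the group at the same place and shifted the number noticeably. Because a 6.0-fold lower number from compound 1 to compound 2 (0.78 log units; beyond the scatter) shows the sulfamoyl group, which carries hydrogen-bond donors, paired with the higher number, a group that again brings a donor is expected to give a somewhat higher number than compound 2, though the change may also stay within the scatter. For compound 3 the estimated step in this assay is a 2.0-fold higher number from compound 2 to compound 3 (0.30 log units; within the scatter). Compound 3 is therefore expected to give about 2 mg/kg, with a range from 0.5 mg/kg to 8 mg/kg.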

Compound 3, dose for half-maximal effect: > 10 mg/kg
Compound 3 ended at the assay's limit; the forecaster's own chance of this, stated with the estimate: 10%; middle value at least 5.0-fold (0.69 log units) away from the limit.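

Compound 3 carries a limit of the assay rather than a number, so its result marks only a floor: the limit of > 10 mg/kg in this assay, at which 1 of the 3 values shown sits. Even so, the exchange of methylsulfanyl for methylamino on a saturated chain carbon, two bonds along the chain from an aromatic nitrogen, gives an at least 10-fold higher number from compound 2 to compound 3 (1.00 log units; beyond the scatter), although the group keeps its 2 heavy atoms and a nitrogen simply takes the place of a sulfur. Against sulfamoyl the reading is less firm, at an at least 1.6-fold higher number from compound 1 to compound 3 (0.22 log units; that floor lies within the scatter), so methylamino and sulfamoyl cannot be told apart here, while methylsulfanyl, the only one of the three groups without a hydrogen-bond donor, stands alone with the lowest number.

From the compounds shown here alone, how far compound 3 lies past the limit stays unknown, and so does the true size of both of its steps. Going by these compounds, whether the donor hydrogen or the nitrogen itself goes with the higher number remains open, and a dimethylamino or methoxy group at this place, or a longer chain ending in methylsulfanyl, would help to separate these readings.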